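A Step From a Compound Without a Number

The compounds below may be only part of what the source reports. "The series", "measured", "known", "first", "only" and "open" are said of these compounds alone.

In a functional assay on HepG2 cells (Homo sapiens) for antiproliferative activity, read by MTT assay, with a stated time of 72 h (on this read-out lower numbers stand for stronger inhibition and higher numbers for weaker inhibition), compound 1 (`O=C(N/N=C/c1ccc([N+](=O)[O-])cc1)Nc1ccc(Oc2ccnc3[nH]ccc23)cc1`) gives 4620 nM. For compound 2 (`O=C(N/N=C/c1ccc(O)cc1Br)Nc1ccc(Oc2ccnc3[nH]ccc23)cc1`) the entry reads "not determined" (no result reported), so it holds no place on the scale and offers no starting value. Compound 3 (`CN(C)CCCn1cccc1/C=N/NC(=O)Nc1ccc(Oc2ccnc3[nH]ccc23)cc1`) carries 1-(3-(dimethylamino)propyl)-1H-pyrrol-2-yl in place of 2-bromo-4-hydroxyphenyl on a carbon with a double bond to nitrogen. Within the data shown here, the only guide is therefore compound 1 at 4620 nM, and from that level a modest step toward stronger inhibition in this assay is expected. Compound 3 is estimated at 2500 nM, with an expected range of 500 nM to 9000 nM.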

Compound 3, half-maximal inhibitory concentration: 4190 nM
Compound 3: the middle estimate sits 1.7-fold (0.22 log units) below what was measured; the measured number falls inside the stated range.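

In this assay, placing 1-(3-(dimethylamino)propyl)-1H-pyrrol-2-yl instead of 4-nitrophenyl on a carbon with a double bond to nitrogen gives a 1.1-fold lower number from compound 1 to compound 3 (0.04 log units; within the scatter) on the shared core, so these two quite different groups cannot be told apart at this position. No measurement on hand offers a reason for this. Among these compounds, compound 2 has no value, so no step involving it can be read. From the compounds shown here alone, whether the pyrrole ring alone, without its chain, would give the same reading stays open, as does the effect of a morpholine in place of the dimethylamino group.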